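The source may report more compounds than this note shows. Statements on the series, on what has been measured and on what is new or still open speak of the compounds shown alone.

Measured compounds in a functional assay on CHO cells for agonist activity at Free fatty acid receptor 1 (Homo sapiens), read by a luciferase reporter, with a stated time of 24 h; a higher number here means that more compound is needed for the effect, a lower number that less compound is needed:
compound 1 `Cc1ccccc1-c1cc2cc(CCC(=O)O)ccc2[nH]1`: 447 nM
compound 2 `COc1ccc(-c2cc3cc(CCC(=O)O)ccc3[nH]2)cc1`: a limit, > 25 nM
compound 3 `Cn1c(-c2ccccc2Br)cc2cc(CCC(=O)O)ccc21`: a limit, > 10000 nM

Within the data shown here, of the three results in this assay, compound 1 is the only one reported as a number. For compound 2 the assay gives only a limit, > 25 nM. For compound 3 likewise only a limit is reported, > 10000 nM. Compound 1 therefore stands alone as the single anchor. Compound 4 `O=C(O)CCc1ccc2[nH]c(-c3ccccc3Cl)cc2c1` has not yet been measured in this assay. It differs from compound 1 in one place: chloro in place of methyl on an aromatic carbon. Among the measured compounds shown here, no two measured compounds differ in a single place, so no measured step exists to lean on; chloro in place of methyl is expected to shift the value little, if at all beyond the usual scatter. Compound 4 is estimated at 400 nM, within a range of 150 nM to 1200 nM. The step of a 1.1-fold lower number from compound 1 to compound 4 (0.05 log units; within the scatter) is thus expected to stay within the scatter.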

Compound 4, half-maximal effective concentration: 54.6 nM
Estimate against measurement, compound 4: 7.3-fold (0.86 log units) above, outside the stated range (below it).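

Changing 2-methylphenyl to 2-chlorophenyl gives an 8.2-fold lower number from compound 1 to compound 4 (0.91 log units; beyond the scatter) in this assay, so this position responds to the exchange of one group for another. The two groups match in what is counted, with one heavy atom each and no hydrogen-bond donors or acceptors, yet the step lies beyond the scatter. Nothing measured here bears on the reason for this step.

The compounds shown leave open whether a fluoro, a trifluoromethyl or a nitrile at this place would also lower the number. They also leave open how a longer chain carrying the carboxylic acid would fare with the 2-chlorophenyl group in place.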